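One Added Methyl on Compound 3

The source may report more compounds than this note shows. Statements on the series, on what has been measured and on what is new or still open speak of the compounds shown alone.

Three related compounds have been measured so far: compound 1 (`O=C1NC(=O)c2c1c1c(c3[nH]c4ccccc4c23)C(=O)CCC1`), compound 2 (`O=C1NC(=O)c2c1c1c(O)cccc1c1[nH]c3ccccc3c21`) and compound 3 (`O=c1ccc(=O)c2c1c1[nH]c3ccccc3c1c1c(=O)[nH]c(=O)c21`). In a functional assay on L1210 cells (Mus musculus) for antiproliferative activity, with a stated time of 4 h (on this read-out higher numbers stand for weaker inhibition and lower numbers for stronger inhibition), compound 1 gives 3700 nM, compound 2 gives 19200 nM and compound 3 gives 6800 nM. The number for compound 3 lies within the usual scatter of the number for compound 1, so those two cannot be told apart. Compound 2 reads higher than compound 3, and that gap goes beyond the scatter.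

Compound 4 (`Cc1ccc2[nH]c3c4c(=O)ccc(=O)c4c4c(=O)[nH]c(=O)c4c3c2c1`) is compound 3 with one change: methyl in place of hydrogen on an aromatic carbon. Among the measured compounds shown here, no two measured compounds differ in one place only, so the data offer no direct guide to this change. With so small an addition, no step beyond the scatter is expected in this assay. The expected step of a 1.1-fold lower number from compound 3 to compound 4 (0.05 log units; within the scatter) stays within the scatter. For compound 4 the estimated value is 6000 nM, with an expected range from 2500 nM to 15000 nM.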

Compound 4, half-maximal inhibitory concentration: 750 nM
Beside the measured number, compound 4's estimate is 8.0-fold (0.90 log units) above it; the measured number lies below the stated range.
By their numbers in this assay, from the lowest: compound 4; then compounds 1 and 3 (each within the scatter of the next); then compound 2.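

Putting methyl in place of hydrogen on an aromatic carbon of the six-membered aromatic ring of carbon only gives, in this assay, a 9.1-fold lower number from compound 3 to compound 4 (0.96 log units; beyond the scatter) and this is the only pair shown that differs in one place. The position is therefore not a silent one: a single added methyl moves the number beyond the usual scatter, towards stronger inhibition. Nothing measured here accounts for the size of this step.

Going by these compounds, whether the same step would come with an ethyl chain, a methoxy group or a chlorine atom at this carbon remains open. So does whether methyl on another carbon of that ring, or on the other compounds shown, would act in the same way, since one step cannot establish a pattern.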